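Swapping the pyrrolidine arm for an acylated proline in compound 3

A few compounds are considered here, and "the series" means these few. Any claim that something is new, unique, unknown or untested is made for them only; others in the source may bear on it.

Among the measured compounds shown here, compound 1 `O=C(CN1CCCC1)N1CCC(NS(=O)(=O)c2cc(S(=O)(=O)c3ccccc3)ccc2C(F)(F)F)CC1` is one of two compounds measured in an assay on isolated protein for binding affinity to secreted frizzled-related protein 1 (Homo sapiens), read by fluorescence (a lower number here means a stronger inhibitor, a higher number a weaker inhibitor), and compound 1 gives 110 nM, the higher of the two numbers. For the measured compounds named here, its only neighbour is compound 2 `O=C(Cn1ccnc1)N1CCC(NS(=O)(=O)c2cc(S(=O)(=O)c3ccccc3)ccc2C(F)(F)F)CC1`, which in this assay gives 30 nM; the step of a 3.7-fold lower number from compound 1 to compound 2 (0.56 log units; beyond the scatter) shows that changing the group on the carbon bound to the carbonyl can move the number by a modest amount.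

Compound 3 `CC(C)C(=O)N1CCC[C@H]1C(=O)N1CCC(NS(=O)(=O)c2cc(S(=O)(=O)c3ccccc3)ccc2C(F)(F)F)CC1` has not yet been measured. It differs from compound 1 as follows: 1-(isopropylcarbonyl)pyrrolidin-2-yl in place of (pyrrolidin-1-yl)methyl on a carbonyl carbon. Going by the values given here, the group that enters is larger than the one that leaves and carries a defined stereocentre and an added carbonyl, so no measured step covers this change directly; the only step at this position, a 3.7-fold lower number from compound 1 to compound 2 (0.56 log units; beyond the scatter), is a small one. A step of similar or smaller size, in either direction, is therefore expected here, with the change a 1.4-fold lower number from compound 1 to compound 3 (0.14 log units; within the scatter) taken as the central guess. For compound 3 in this assay the expected number is 80 nM, with a range from 25 nM to 250 nM.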

Compound 3, half-maximal inhibitory concentration: 40 nM
For compound 3 the middle estimate is 2.0-fold (0.30 log units) above the measured one; low and high end bracket the measured number.
By their numbers in this assay, from the lowest: compounds 2 and 3 (each within the scatter of the next); then compound 1.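

In this assay, putting the larger 1-(isopropylcarbonyl)pyrrolidin-2-yl on the carbonyl carbon in place of (pyrrolidin-1-yl)methyl gives a 2.8-fold lower number from compound 1 to compound 3 (0.44 log units; beyond the scatter), so this position accepts a group with more heavy atoms, an added carbonyl and a defined stereocentre without the number rising. The comparison with the imidazole compound gives a 1.3-fold higher number from compound 2 to compound 3 (0.12 log units; within the scatter), which means that two quite different groups end up level within the scatter, and both give lower numbers than the (pyrrolidin-1-yl)methyl group of compound 1. No measurement available here gives a reason for these differences.

The compounds shown leave open which part of the entering group matters: a free secondary amine in the pyrrolidine ring, with a plain hydrogen in place of the isopropylcarbonyl, or a smaller acetyl group on that nitrogen would separate the effect of the acyl group from that of the ring. They also leave open what the mirror-image form of the stereocentre would give, since only one arrangement appears among these compounds.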